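Phenyl in place of cyclopropyl on the ether carbon

The compounds below may be only part of what the source reports. "The series", "measured", "known", "first", "only" and "open" are said of these compounds alone.

Compound 3 `S=C(Nc1cccnc1)NC1CCN(c2cc(OCC3CC3)ccn2)CC1` gives 4700 nM in an assay on membranes from brain for binding affinity to Lysophosphatidylserine lipase ABHD12 (Mus musculus), read by fluorescence, with a stated time of 20 min; a lower number here means a stronger inhibitor, a higher number a weaker inhibitor. Among the two numbers measured it stands highest; its nearest neighbour is compound 2 `FC(F)(F)c1ccnc(N2CCC(NC(=S)Nc3cccnc3)CC2)c1`, which gives 640 nM, and the step of a 7.3-fold higher number from compound 2 to compound 3 (0.87 log units; beyond the scatter) is modest. Compound 1 `COc1ccnc(N2CCC(NC(=S)Nc3cccnc3)CC2)c1` gives only a limit of > 5000 nM in this assay, as noted in the limit of > 5000 nM in this assay, at which 1 of the 3 values shown sits. From that limit the step of an at least 7.8-fold lower number from compound 1 to compound 2 (0.89 log units; beyond the scatter) is at least modest, while the step of an at least 1.0-fold lower number from compound 1 to compound 3 (0.02 log units; that floor lies within the scatter) has a floor that lies within the scatter.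

Compound 4 `S=C(Nc1cccnc1)NC1CCN(c2cc(OCc3ccccc3)ccn2)CC1` differs from compound 3 in one place: phenyl in place of cyclopropyl on a saturated chain carbon bound to an oxygen on an aromatic ring. Among the compounds with values here, the only measured step at the same position is the step from compound 1 to compound 3, where cyclopropyl replaced hydrogen, and it lies at a floor within the scatter. Within the data shown here, no measured step exchanges cyclopropyl for phenyl, so the expectation rests on that single step alone. The estimated step of a 1.3-fold lower number from compound 3 to compound 4 (0.13 log units; within the scatter) is expected to stay within the scatter. In this assay compound 4 is therefore estimated at 3500 nM, with a range from 1000 nM to 12000 nM.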

Compound 4, half-maximal inhibitory concentration: 2800 nM
Beside the measured number, compound 4's estimate is 1.3-fold (0.10 log units) above it; low and high end bracket the measured number.
By their numbers in this assay, from the lowest: compound 2; then compounds 4 and 3 (each within the scatter of the next). At a limit, above all of these: compound 1.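

In this assay, phenyl in place of cyclopropyl on a saturated chain carbon bound to an oxygen on an aromatic ring gives a 1.7-fold lower number from compound 3 to compound 4 (0.22 log units; within the scatter), so the two numbers stay within the scatter of each other. Benzyloxy does not reach trifluoromethyl on the aromatic carbon, the step being a 4.4-fold higher number from compound 2 to compound 4 (0.64 log units; beyond the scatter), so compound 4 joins compound 3 in standing apart from compound 2. Going by these compounds, compound 1 stands at a limit: the limit of > 5000 nM in this assay, at which 1 of the 4 values shown sits. From that limit, phenyl in place of hydrogen on a saturated chain carbon bound to an oxygen on an aromatic ring gives an at least 1.7-fold lower number from compound 1 to compound 4 (0.25 log units; that floor lies within the scatter), and the true size of this step stays open.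

On these data alone, it remains open whether an amine or a carboxylic acid in place of phenyl on that carbon, or a longer chain there, would move the number. The compounds shown also do not tell whether any ether at this place can match compound 2.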